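The source may hold more compounds than are shown below. What is called first, only, known or untested is meant among the compounds shown, and "the series" means these compounds.

In a toxicity assay on microsomes from liver (Homo sapiens) for metabolic stability, read by LC-MS, using NADPH, tested at 1 uM (a lower number here means slower removal, a higher number faster removal of the compound), compound 1 `COc1ncc(-c2nc(C(F)(F)F)sc2N2CCN(C(=O)Cn3cnc4cccnc43)[C@H](C)C2)cn1` gives 0.014 mL/min/kg, and compound 2 `CCOc1ncc(-c2nc(C(F)(F)F)sc2N2CCN(C(=O)Cn3cnc4cccnc43)[C@H](C)C2)cn1` gives 0.075 mL/min/kg, the higher of the two numbers. Compound 3 `Cc1ncc(-c2nc(C(F)(F)F)sc2N2CCN(C(=O)Cn3cnc4cccnc43)[C@H](C)C2)cn1` has methyl in place of ethoxy on an aromatic carbon. Within the data shown here, only one measured step lies at this place, a 5.4-fold higher number from compound 1 to compound 2 (0.73 log units; beyond the scatter), modest and beyond the scatter. It is a different change, so it guides only loosely, but it suggests a modest move to a lower number in this assay. The estimated step is a 2.5-fold lower number from compound 2 to compound 3 (0.40 log units; beyond the scatter). For compound 3 the expected value is 0.03 mL/min/kg, with an estimated range of 0.008 mL/min/kg to 0.11 mL/min/kg.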

Compound 3, clearance: 0.033 mL/min/kg
The estimate for compound 3 lay 1.1-fold (0.04 log units) below the measured number, within the range that was stated.
By their numbers in this assay, from the lowest: compound 1; then compound 3; then compound 2.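

In this assay, methyl on the aromatic carbon between two ring nitrogen atoms lands inside the span set by the two ether groups, with a 2.3-fold lower number from compound 2 to compound 3 (0.36 log units; beyond the scatter) and a 2.4-fold higher number from compound 1 to compound 3 (0.37 log units; beyond the scatter). Across these three compounds, then, the number does not simply follow the presence of the ether oxygen, since the oxygen-free methyl falls between methoxy and ethoxy. Nothing available accounts for this order. Open, on these data alone, is how an amine or a longer chain such as propoxy at this carbon would compare. A single change at this place also leaves open whether the order holds on other versions of the shared core.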